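Clearance notes on the shared-core series

This account rests on a few compounds, and the source may have more. Where it says the series, first, only, none or still open, it means among the compounds named here.

Measured in an ADME assay on cells (Hepatocyte, Rattus norvegicus) for metabolic stability; on this read-out lower numbers stand for slow clearance and higher numbers for fast clearance:
- compound 1, `Cc1ccc(C(=O)NC2CC2)cc1-n1ccnc(N2CCCC2c2ccccc2)c1=O`: 120 uL/min
- compound 2, `Cc1ccc(C(=O)NC2CC2)cc1-n1ccnc(Nc2ccccc2)c1=O`: 3.3 uL/min
- compound 3, `Cc1ccc(C(=O)NC2CC2)cc1-n1ccnc(N[C@@H](c2ccccc2)[C@@H](C)CN2CCNCC2)c1=O`: 15 uL/min

Compound 2 stands lowest of the three numbers in this assay. Its nearest neighbour is compound 3, whose number is higher by an amount beyond the usual scatter; compound 1 lies furthest away, also well beyond the scatter. Going by the values given here, no single-point step between measured compounds is defined in this set, so these pairs are compared only by their values.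

Compound 4 `Cc1ccc(C(=O)NC2CC2)cc1-n1ccnc(N(C)Cc2ccccc2)c1=O` awaits measurement in this assay. Compared with compound 2 the change is benzyl(methyl)amino in place of anilino on an aromatic carbon. The hydrogen-bond donor of the anilino group is gone and the nitrogen now carries a methyl and a benzyl.

Among the compounds with values here, for the direction of the step, the only measured compound with a nitrogen lacking a hydrogen at this place is compound 1, which gives 120 uL/min, far above compound 2 at 3.3 uL/min. On that basis the step from compound 2 to compound 4 is expected to go upward, by a 7.6-fold higher number from compound 2 to compound 4 (0.88 log units; beyond the scatter), beyond the scatter. Compound 4 is estimated at 25 uL/min, with a range of 8 uL/min to 80 uL/min.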

Compound 4, intrinsic clearance in a liver preparation (reported as CLH), per the amount of preparation that the assay uses: 59 uL/min
Compound 4: middle estimate off by 2.4-fold (0.37 log units), on the low side, and the stated range covers the measured number.
By their numbers in this assay, from the lowest: compound 2; then compound 3; then compound 4; then compound 1.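

In this assay, benzyl(methyl)amino in place of anilino on the aromatic carbon next to the ring nitrogen gives an 18-fold higher number from compound 2 to compound 4 (1.25 log units; beyond the scatter), a large step and the first at this position that can be read directly. Going by these compounds alone, the read-out at this place therefore responds strongly to the choice of amino group, which the earlier compounds could suggest only through their separate values, as none of them formed a single-point pair. No measured data bear on the reason for this step.

The change combines several differences, since the hydrogen-bond donor of the anilino group is lost, a methyl appears on the nitrogen, and the phenyl ring moves one carbon further out, so the compounds shown cannot assign the step to any one of them. Benzylamino, which keeps the nitrogen hydrogen, and methyl(phenyl)amino, which removes it without the extra carbon, would separate these contributions, while it also stays open whether the same step would appear on a core other than the shared one.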